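Swapping Chloro for Trifluoromethyl on a Lyase Inhibitor Core

A few compounds are considered here, and "the series" means these few. Any claim that something is new, unique, unknown or untested is made for them only; others in the source may bear on it.

In an assay on Sf9 cells for inhibition of sphingosine-1-phosphate lyase 1 (Homo sapiens), with a stated time of 1 h (on this read-out lower numbers stand for stronger inhibition and higher numbers for weaker inhibition), compound 3 `C[C@@H]1CN(c2nnc(Cc3ccccc3)c3cc(Cl)ccc23)CCN1c1ccc(C#N)cn1` gives 2300 nM, the highest of the two numbers recorded so far. Its nearest neighbour, compound 1 `C[C@@H]1CN(c2nnc(Cc3ccccc3)c3ccccc23)CCN1c1ccc([N+](=O)[O-])cn1`, gives 740 nM, a gap that lies beyond the usual scatter. Compound 2 `C[C@@H]1CN(c2nnc(-c3ccccc3)c3ccccc23)CCN1c1ccc(C#N)cn1` gives only a limit of the assay, > 30000 nM. Compound 4 `C[C@@H]1CN(c2nnc(Cc3ccccc3)c3cc(C(F)(F)F)ccc23)CCN1c1ccc(C#N)cn1` has not yet been measured; it differs from compound 3 by trifluoromethyl in place of chloro on an aromatic carbon. Among the measured compounds shown here, no pair of measured compounds shares this single change, so no measured step guides the expectation, and a shift no larger than the scatter is expected, in either direction. Compound 4 is therefore expected to give about 2500 nM, between 800 nM and 8000 nM, an expected step of a 1.1-fold higher number from compound 3 to compound 4 (0.04 log units; within the scatter).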

Compound 4, half-maximal inhibitory concentration: 12000 nM
Compound 4: middle estimate off by 4.8-fold (0.68 log units), on the low side; measured number outside the range, above it.
By their numbers in this assay, from the lowest: compound 1; then compound 3; then compound 4. At a limit, above all of these: compound 2.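

In this assay, trifluoromethyl in place of chloro gives a 5.2-fold higher number from compound 3 to compound 4 (0.72 log units; beyond the scatter). This position on the shared core is therefore not indifferent to what it carries, and here the swap weakens inhibition. Compound 4 still gives a true number, whereas compound 2 stands at a limit of the assay, not a number: the limit of > 30000 nM in this assay, at which 1 of the 4 values shown sits.

The compounds shown leave open how a fluoro group, a methoxy group or an amine would read at this place. One step alone cannot say whether chloro itself helps inhibition or trifluoromethyl only harms it.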